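Propoxy in place of fluorine: expected cytotoxicity of compound 4

The source may report more compounds than this note shows. Statements on the series, on what has been measured and on what is new or still open speak of the compounds shown alone.

Measured compounds:
compound 1 `COC(=O)c1cc(-c2cccc(NC(=O)c3ccc(/C=C/C(=O)c4cccc(F)c4)cc3)c2)on1`: > 40 ug/mL
compound 2 `COC(=O)c1cc(-c2cccc(NC(=O)c3ccc(/C=C/C(=O)c4cccs4)cc3)c2)on1`: "not determined" (no result reported)
compound 3 `COC(=O)c1cc(-c2cccc(NC(=O)c3ccc(/C=C/C(=O)c4ccc(F)cc4)cc3)c2)on1`: > 20 ug/mL

In an ADME assay on Vero cells (Chlorocebus sabaeus) for cytotoxicity, read by MTT assay, with a stated time of 72 h (on this read-out lower numbers stand for higher toxicity in this test and higher numbers for lower toxicity in this test), compound 1 gives > 40 ug/mL; this is a limit of the assay and not a number. For compound 2 no result is reported in this assay, the entry reads "not determined" (no result reported). Compound 3 gives > 20 ug/mL in this assay, and this too is a limit. The step that the two limits leave unreadable from compound 1 to compound 3 is therefore unreadable in size. Compound 3 thus stands at a limit, with one further value also a limit (the limit of > 40 ug/mL in this assay, at which 1 of the 3 values shown sits) and one entry without a number; its own limit is the limit of > 20 ug/mL in this assay, at which 1 of the 3 values shown sits.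

Compound 4 `CCCOc1ccc(C(=O)/C=C/c2ccc(C(=O)Nc3cccc(-c4cc(C(=O)OC)no4)c3)cc2)cc1` differs from compound 3 by propoxy in place of fluoro on an aromatic carbon. Among the compounds with values here, no measured step bears on this change: the only measured step, a step that the two limits leave unreadable from compound 1 to compound 3, has two limits at its ends and cannot be read. No step beyond the scatter is expected in this assay in either direction, and the estimated step is a step that the limit leaves unreadable from compound 3 to compound 4. Compound 4 is expected to give 40 ug/mL, with a range from 15 ug/mL to 100 ug/mL.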

Compound 4, half-maximal cytotoxic concentration: > 40 ug/mL
Compound 4 was reported as a limit (the forecaster's own chance of this, stated with the estimate: 65%); the middle value lies on the limit itself.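

Within the data shown here, no step among compound 1, compound 3 and compound 4 can be read in this assay: all three results are limits of the assay and not numbers. The compounds shown leave open how far each actual value lies from its limit, and whether propoxy in place of fluoro shifts cytotoxicity at all.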